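Shifting One Fluorine on the Phenyl Group

The source may hold more compounds than are shown below. What is called first, only, known or untested is meant among the compounds shown, and "the series" means these compounds.

Among the compounds with values here, only two compounds have been tested in a functional assay on SK-MEL-2 cells (Homo sapiens) (on this read-out lower numbers stand for an effect already at smaller amounts and higher numbers for an effect only at larger amounts of compound), and neither gives an exact number. Compound 1 (`Oc1nc(-c2ccc(F)cc2)nc2ccccc12`) gives > 20 ug/mL, which is a limit of the assay. Compound 2 (`COc1cc2nc(-c3ccccc3F)nc(O)c2cc1OC`) gives < 5 ug/mL, which is also a limit. Going by these compounds, the two limits do not overlap, but the true value of compound 2 remains unknown.

Compound 3 (`COc1cc2nc(-c3ccc(F)cc3)nc(O)c2cc1OC`) has not yet been measured. It differs from compound 2 in one place, with 4-fluorophenyl in place of 2-fluorophenyl on an aromatic carbon. The two have the same atoms, joined differently. Within the data shown here, no measured pair shows what this change does in this assay, so no firm direction can be expected. The expected step is a step that the limit leaves unreadable from compound 2 to compound 3, no larger than the usual scatter. For compound 3 the estimated value is 4 ug/mL, with an expected range from 1.5 ug/mL to 12 ug/mL.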

Compound 3, concentration for half-maximal effect: > 20 ug/mL
Compound 3 was reported as a limit (the forecaster's own chance of this, stated with the estimate: 45%); middle value at least 5.0-fold (0.69 log units) away from the limit.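

In this assay, exchanging 2-fluorophenyl for 4-fluorophenyl on this aromatic carbon, with the same atoms joined differently, gives an at least 4.0-fold higher number from compound 2 to compound 3 (0.60 log units; beyond the scatter). Within the data shown here, this is the first measured pair that differs in one place, and it shows that where a single fluorine sits on the phenyl group changes the read-out beyond the scatter. The true size of the step remains unknown because compound 3 sits at a limit and not at an exact number: the limit of > 20 ug/mL in this assay, at which 2 of the 3 values shown sit.

Going by these compounds, whether the gap depends on fluorine itself stays open, and a plain phenyl group or a 2-chlorophenyl group on this carbon would address that. On these data alone, the part played by the two methoxy groups of compound 2 and compound 3 also stays open: compound 1 differs from both in more than one place.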